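The source may report more compounds than this note shows. Statements on the series, on what has been measured and on what is new or still open speak of the compounds shown alone.

Working notes on the series.

Within the data shown here, compound 1 `COc1cc(C)cc(-c2c(-c3ccnc(-c4ccc(N(C)C)cc4)c3)cnn2CC#N)c1` is the one member that returns a number: in a functional assay on K562 cells (Homo sapiens) for inhibition, read by sulforhodamine B assay, with a stated time of 48 h (on this read-out lower numbers stand for stronger inhibition of growth and higher numbers for weaker inhibition of growth), compound 1 gives 3820 nM. Compound 2 `COc1cc(C)cc(-c2nn(CC#N)cc2-c2ccnc(-c3ccc(N(C)C)cc3)c2)c1` carries the same substituents arranged differently around the shared core. In this assay compound 2 gives > 100000 nM, which is a limit of the assay and not a number. Compound 3 `COc1cc(C)cc(-c2nn(CC#N)cc2-c2ccc(-c3cccc(C(C)=O)c3)nc2)c1` is built on the core of compound 2 with a different aryl partner. In this assay compound 3 gives > 100000 nM, again a limit and not a number. Compound 2 thus stands at the limit of > 100000 nM in this assay, at which 2 of the 3 values shown sit, so its true position is not fixed and only its side of the limit is known.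

Compound 4 `Cc1cc(O)cc(-c2nn(CC#N)cc2-c2ccnc(-c3ccc(N(C)C)cc3)c2)c1` is to be measured. It differs from compound 2 by hydrogen in place of methyl on an oxygen on an aromatic ring. Among the measured compounds shown here, no step between measured compounds touches this oxygen, so no size can be read from the data for it. Since compound 2 sits at a limit, the expected step from compound 2 to compound 4 in this assay is none beyond the scatter, given as a number no higher from compound 2 to compound 4 (the limit leaves the size open). The estimate for compound 4 in this assay is 100000 nM, expected to fall between 30000 nM and 300000 nM, most probably again reported as a limit.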

Compound 4, concentration for total growth inhibition: 32800 nM
The estimate for compound 4 lay 3.0-fold (0.48 log units) above the measured number; low and high end bracket the measured number.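

In this assay, the change from 3-methoxy-5-methylphenyl to 3-hydroxy-5-methylphenyl gives an at least 3.0-fold lower number from compound 2 to compound 4 (0.48 log units; beyond the scatter), which shows that this oxygen on an aromatic ring is a place where a single change moves the read-out on the core of compound 2. Among these compounds, compound 4 gives 32800 nM, the first actual number on that core, so growth inhibition on this core can now be followed by measured values. Compound 2 stands at a limit, so the step gives only the least size of the change and not its full size: the limit of > 100000 nM in this assay, at which 2 of the 4 values shown sit.

The compounds shown leave open whether the step depends on the hydroxy as such, which an amine or a carboxylic acid in its place on the ring would test, and whether a longer chain on the oxygen, such as ethoxy, would read like methoxy or like hydroxy. They also leave open whether the same change from methoxy to hydroxy on the core of compound 1 would give a step of similar size.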